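The source may hold more compounds than are shown below. What is called first, only, known or untested is meant among the compounds shown, and "the series" means these compounds.

Compound 1 `O=C(/C(=C\c1ccc(Br)cc1)S(=O)(=O)c1ccc(Br)cc1)c1ccc(Br)cc1` gives 10000 nM in a functional assay on DU-145 cells (Homo sapiens) for inhibition, read by trypan blue exclusion, with a stated time of 96 h (a lower number here means a stronger inhibitor of growth, a higher number a weaker inhibitor of growth), the lowest of the two exact numbers available. Compound 2 `O=C(/C(=C\c1ccc(OC(F)(F)F)cc1)S(=O)(=O)c1ccc(Br)cc1)c1ccc(Br)cc1` gives 25000 nM in the same test. Compound 3 `O=C(/C(=C\c1ccc(Br)cc1)S(=O)(=O)c1ccc(Br)cc1)c1ccccc1O` reaches only a limit of the assay, > 100000 nM.

The unmeasured compound 4 `COc1ccc(/C=C(\C(=O)c2ccc(Br)cc2)S(=O)(=O)c2ccc(Br)cc2)c(OC)c1` differs from compound 1 in one group: 2,4-dimethoxyphenyl in place of 4-bromophenyl on a double-bonded chain carbon bound to a double-bonded chain carbon. In words, 2,4-dimethoxyphenyl takes the place of 4-bromophenyl on a double-bonded chain carbon bound to a double-bonded chain carbon.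

For the measured compounds named here, two measured steps bear on this change. The closer one, a 2.5-fold higher number from compound 1 to compound 2 (0.40 log units; beyond the scatter), puts trifluoromethoxy in place of bromo on an aromatic carbon of the group that compound 4 also alters. The other, an at least 10-fold higher number from compound 1 to compound 3 (1.00 log units; beyond the scatter), changes a different place, the group on the carbonyl carbon, so it offers only looser guidance. Going by the values given here, both steps lead to higher numbers, and no measured compound has a lower number than compound 1. Among the compounds with values here, no measured compound carries a methoxy group, so the estimate stays wide.

A modest rise is therefore expected in this assay, towards weaker growth inhibition. The estimated change is a 2.0-fold higher number from compound 1 to compound 4 (0.30 log units; within the scatter). For compound 4 the expected value is 20000 nM, within an estimated range of 4000 nM to 80000 nM.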

Compound 4, concentration for 50% growth inhibition: 8000 nM
For compound 4 the middle estimate is 2.5-fold (0.40 log units) above the measured one; measured number inside the range.
By their numbers in this assay, from the lowest: compounds 4 and 1 (each within the scatter of the next); then compound 2. At a limit, above all of these: compound 3.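

In this assay, exchanging the whole 4-bromophenyl for 2,4-dimethoxyphenyl on a double-bonded chain carbon bound to a double-bonded chain carbon gives a 1.3-fold lower number from compound 1 to compound 4 (0.10 log units; within the scatter), so compound 1 and compound 4 cannot be told apart in this test. For the compounds shown here, the only earlier change at this group, a 2.5-fold higher number from compound 1 to compound 2 (0.40 log units; beyond the scatter), altered one substituent and left a rise beyond the scatter, whereas compound 4 shows that not every change here raises the number: this place accepts a group that has no bromine and carries hydrogen-bond acceptors that 4-bromophenyl lacks, and the growth-inhibition reading holds. Nothing shown here gives a reason why the dimethoxy group holds the reading while trifluoromethoxy raises it.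

With both methoxy groups entering together, the compounds shown leave open what each one contributes, and whether a single methoxy group would behave the same way. From the compounds shown here alone, how an amine or a carboxylic acid on this ring would read also remains open, as does whether this tolerance would hold with the other two rings of the shared core changed.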